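Dropping One Chloro Group from the Aniline Ring

A few compounds are considered here, and "the series" means these few. Any claim that something is new, unique, unknown or untested is made for them only; others in the source may bear on it.

In a functional assay on NCI-H522 cells (Homo sapiens) for inhibition, read by sulforhodamine B assay, with a stated time of 48 h (a higher number here means a weaker inhibitor of growth, a lower number a stronger inhibitor of growth), compound 2 `CN1CCN(CCCOc2cccc3nc(Nc4cc(Cl)cc(Cl)c4)ccc23)CC1` gives 1640 nM, the lower of the two numbers recorded, while compound 1 `CN1CCN(CCCOc2cccc3nc(Nc4ccc(Cl)c(F)c4)ccc23)CC1` gives 1750 nM. Going by the values given here, the only measured step, a 1.1-fold lower number from compound 1 to compound 2 (0.03 log units; within the scatter), is within the scatter, so the two are not separated. Compound 3 `CN1CCN(CCCOc2cccc3nc(Nc4cccc(Cl)c4)ccc23)CC1` differs from compound 2 by hydrogen in place of chloro on an aromatic carbon. Among the compounds with values here, no measured step removes a chloro group, and the one swap of aryl groups seen barely moved the number, so only a small change, if any, is expected. Compound 3 is estimated at 2000 nM, between 900 nM and 4500 nM. The step this estimate implies is a 1.2-fold higher number from compound 2 to compound 3 (0.09 log units; within the scatter).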

Compound 3, concentration for 50% growth inhibition: 1480 nM
For compound 3 the middle estimate is 1.4-fold (0.13 log units) above the measured one; measured number inside the range.
By their numbers in this assay, from the lowest: compounds 3, 2 and 1 (each within the scatter of the next).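

Taking off the second chloro group gives a 1.1-fold lower number from compound 2 to compound 3 (0.04 log units; within the scatter) in this assay, so this change does not separate the two compounds. Comparing the 3-chlorophenyl and 4-chloro-3-fluorophenyl groups gives a 1.2-fold lower number from compound 1 to compound 3 (0.07 log units; within the scatter) as well, so among these three compounds a second halogen on this ring makes no readable difference. Nothing available explains this flat result. Still open, on these data alone, is whether a different kind of group at this carbon, such as a methoxy group, a nitrile or an amine, would separate from these compounds. As far as these compounds go, the effect of losing the remaining chloro group is also open.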